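Methyl on the phenol ring: carrying a step across two series

This account rests on a few compounds, and the source may have more. Where it says the series, first, only, none or still open, it means among the compounds named here.

Measured compounds, all in an assay on liver for inhibition of sterol O-acyltransferase 1 (Rattus norvegicus), using microsomes; on this read-out higher numbers stand for weaker inhibition and lower numbers for stronger inhibition:
- compound 1, `CC(C)c1cccc(C(C)C)c1NS(=O)(=O)NC(=O)Oc1c(C(C)(C)C)cccc1C(C)(C)C`, gives 16800 nM
- compound 2, `CC(C)(C)c1cccc(C(C)(C)C)c1OC(=O)NS(=O)(=O)NC(c1ccccc1)c1ccccc1`, gives 11400 nM
- compound 3, `Cc1cc(C(C)(C)C)c(OC(=O)NS(=O)(=O)Nc2c(C(C)C)cccc2C(C)C)c(C(C)(C)C)c1`, gives 13500 nM

All three numbers in this assay lie close together. Compound 2 has the lowest number of the three, but its distance to compound 3 and to compound 1 is within the scatter, so no order among them can be read from the data.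

Compound 1 and compound 3 differ in one place: methyl in place of hydrogen on an aromatic carbon. That change produced a 1.2-fold lower number from compound 1 to compound 3 (0.09 log units; within the scatter), a step too small to be distinguished from repeat measurement.

The difference between the core of compound 1 and the core of compound 2 is not broken down here; the two differ in more than one place.

Compound 4, `Cc1cc(C(C)(C)C)c(OC(=O)NS(=O)(=O)NC(c2ccccc2)c2ccccc2)c(C(C)(C)C)c1`, has not yet been measured in this assay. It stands to compound 2 as compound 3 stands to compound 1: methyl in place of hydrogen on an aromatic carbon. The place descriptions of the two changes agree word for word, so this is the same change made on a second core.

Because the earlier instance of the change gave a 1.2-fold lower number from compound 1 to compound 3 (0.09 log units; within the scatter), the corresponding step from compound 2 is expected to be about as small: a 1.1-fold lower number from compound 2 to compound 4 (0.06 log units; within the scatter). On that basis compound 4 is estimated at 10000 nM in this assay, with a range from 5000 nM to 22000 nM; the range is set wide since one prior instance of the change is the only support.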

Compound 4, half-maximal inhibitory concentration: 11500 nM
Compound 4: the middle estimate sits 1.2-fold (0.06 log units) below what was measured; the measured number falls inside the stated range.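

In this assay, the new step, a 1.0-fold higher number from compound 2 to compound 4 (0.00 log units; within the scatter), is as small as the earlier one, and the two instances of methyl in place of hydrogen, meta to two tert-butyl groups and para to a large group, agree: the same change on two cores in this assay, a 1.2-fold lower number (0.09 log units; within the scatter) from compound 1 to compound 3 and a 1.0-fold higher number (0.00 log units; within the scatter) from compound 2 to compound 4, 1.3-fold (0.10 log units) apart, within the scatter of two such steps. On these two cores the change therefore carries over as a step that cannot be told from repeat measurement, so the small step seen on the first core was a fair guide to the second. This does not show that the methyl has any effect of its own, nor that a larger step would carry across in the same way, and two steps this small say nothing about other cores in the series.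

The compounds shown leave open whether any group at this place moves the number beyond the scatter, as a methoxy group, an amine or a carboxylic acid in place of the methyl might or might not do. From the compounds shown here alone, all four compounds also carry both tert-butyl groups, and what an ethyl group in their place would give remains open.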